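Swapping a Carbon Ring for Morpholine: Effect on Solubility

A few compounds are considered here, and "the series" means these few. Any claim that something is new, unique, unknown or untested is made for them only; others in the source may bear on it.

For the measured compounds named here, compound 2 `CC(C)(C)c1cc(NC(=O)[C@@H]2CCCCN2C(=O)C2CCCCC2)no1` gives 6.4 ug/mL in a physicochemical assay for solubility, read by HPLC, at pH 6.8 (on this read-out lower numbers stand for lower solubility and higher numbers for higher solubility), the lowest of the two numbers measured so far; compound 1 `CC(C)CN1CCCC[C@H]1C(=O)Nc1cc(C(C)(C)C)on1` gives 32 ug/mL. Going by the values given here, the only measured step, a 5.0-fold lower number from compound 1 to compound 2 (0.70 log units; beyond the scatter), concerns a different kind of change on the ring nitrogen, so no step of the same kind as the one that follows is available. Compound 3 `CC(C)(C)c1cc(NC(=O)[C@@H]2CCCCN2C(=O)N2CCOCC2)no1` differs from compound 2 by morpholin-4-yl in place of cyclohexyl on a carbonyl carbon. Without a matching precedent the direction is uncertain, yet a higher number is expected. Compound 3 is estimated at 25 ug/mL, within 8 ug/mL to 80 ug/mL. That expectation corresponds to a step of a 3.9-fold higher number from compound 2 to compound 3 (0.59 log units; beyond the scatter).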

Compound 3, solubility: 45 ug/mL
Compound 3: the middle estimate sits 1.8-fold (0.26 log units) below what was measured, and the stated range covers the measured number.
By their numbers in this assay, from the lowest: compound 2; then compounds 1 and 3 (each within the scatter of the next).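

For the compounds shown here, on a carbonyl carbon, morpholin-4-yl in place of cyclohexyl comes with a 7.0-fold higher number from compound 2 to compound 3 (0.85 log units; beyond the scatter) in this assay, the first reading of a change at this place. Replacing isobutyl on the amine nitrogen in a ring with (morpholin-4-yl)carbonyl gives a 1.4-fold higher number from compound 1 to compound 3 (0.15 log units; within the scatter), so these two compounds cannot be told apart on this read-out. Nothing available here explains either step. Still open, going by these compounds, is how piperidin-1-yl or dimethylamino on the same carbonyl carbon would read, and so whether the step goes with the oxygen or the nitrogen of morpholin-4-yl.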